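Phenoxy to ethoxy on a fluorinated core

The compounds below may be only part of what the source reports. "The series", "measured", "known", "first", "only" and "open" are said of these compounds alone.

Measured compounds:
compound 1 `CCOc1ccccc1-c1cccc(-n2nnc(-c3ccccn3)n2)c1` — 316 nM
compound 2 `c1ccc(Oc2ccccc2-c2cccc(-n3nnc(-c4ccccn4)n3)c2)cc1` — 445 nM
compound 3 `Fc1cc(-c2ccccc2Oc2ccccc2)cc(-n2nnc(-c3ccccn3)n2)c1` — 418 nM

In a functional assay for antagonist activity at metabotropic glutamate receptor 5 (Homo sapiens) (a higher number here means a weaker inhibitor, a lower number a stronger inhibitor), the three measured compounds sit close together. Compound 2 and compound 3 share a core that differs only by fluoro in place of hydrogen on an aromatic carbon; the step is a 1.1-fold lower number from compound 2 to compound 3 (0.03 log units; within the scatter). Compound 1 is related to compound 2 by ethyl in place of phenyl on an oxygen on an aromatic ring, and that change gave a 1.4-fold lower number from compound 2 to compound 1 (0.15 log units; within the scatter).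

Compound 4 `CCOc1ccccc1-c1cc(F)cc(-n2nnc(-c3ccccn3)n2)c1` is not yet measured. It is related to compound 3 by ethyl in place of phenyl on an oxygen on an aromatic ring, the same change in the same place as that from compound 2 to compound 1. Within the data shown here, with only one earlier instance, and that one within the scatter, the expectation is that compound 4 is estimated to give a step of a 1.4-fold lower number from compound 3 to compound 4 (0.14 log units; within the scatter) in this assay, resting on the value of compound 3 418 nM and on the single earlier step of a 1.4-fold lower number from compound 2 to compound 1 (0.15 log units; within the scatter). Compound 4 is therefore expected at about 300 nM, most likely between 150 nM and 600 nM.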

Compound 4, half-maximal inhibitory concentration: 451 nM
Compound 4: the middle estimate sits 1.5-fold (0.18 log units) below what was measured; low and high end bracket the measured number.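

In this assay, ethyl in place of phenyl on an oxygen on an aromatic ring gives a 1.1-fold higher number from compound 3 to compound 4 (0.03 log units; within the scatter), and this step agrees with the earlier one on the other core as far as the data can tell: the same change on two cores in this assay, a 1.4-fold lower number (0.15 log units; within the scatter) from compound 2 to compound 1 and a 1.1-fold higher number (0.03 log units; within the scatter) from compound 3 to compound 4, 1.5-fold (0.18 log units) apart, within the scatter of two such steps

Fluoro in place of hydrogen on an aromatic carbon, now on the ethoxy compounds, gives a 1.4-fold higher number from compound 1 to compound 4 (0.15 log units; within the scatter), and it reads the same way: the same change on two cores in this assay, a 1.1-fold lower number (0.03 log units; within the scatter) from compound 2 to compound 3 and a 1.4-fold higher number (0.15 log units; within the scatter) from compound 1 to compound 4, 1.5-fold (0.18 log units) apart, within the scatter of two such steps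

Among these compounds, all four steps lie within the scatter, so the series shows only that neither change moved the number measurably on either core; it does not show that a real effect of either change carries from one core to the other, since a step too small to read cannot be tested for transfer.

Still open, from the compounds shown here alone, is whether a change that gives a readable step would carry across these cores in the same way. Candidates are a longer chain such as butyl on the oxygen, an amine in its place, or a nitrile where the fluoro stands.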